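The compounds below may be only part of what the source reports. "The series", "measured", "known", "first", "only" and "open" are said of these compounds alone.

Measured in a functional assay, read by spectrophotometry, with a stated time of 15 min; a lower number here means a stronger inhibitor, a higher number a weaker inhibitor:
compound 1, `Cc1nc2c3ccccc3ccc2c2nc3c(ccc4ccccc43)c(-c3cccnc3)c12`, 63.6 ug/mL
compound 2, `COc1ccc(-c2c3ccc4ccccc4c3nc3c2c(C)nc2c4ccccc4ccc32)cc1`, 82.3 ug/mL
compound 3, `Cc1nc2c3ccccc3ccc2c2nc3c(ccc4ccccc43)c(-c3ccccc3S)c12`, 49.6 ug/mL

Among these three, compound 1 stands second highest. Its nearest neighbour is compound 3, with a 1.3-fold lower number from compound 1 to compound 3 (0.11 log units; within the scatter), and its furthest is compound 2, with a 1.3-fold higher number from compound 1 to compound 2 (0.11 log units; within the scatter). The remaining pair shows a 1.7-fold lower number from compound 2 to compound 3 (0.22 log units; within the scatter). All three compounds carry a different group on the same aromatic carbon of the shared core, and none of these exchanges moves the number beyond the scatter.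

Compound 4, `Cc1nc2c3ccccc3ccc2c2nc3c(ccc4ccccc43)c(-c3cc(O)nc4ccccc34)c12`, has not yet been measured. It differs from compound 1 in one place: 2-hydroxyquinolin-4-yl in place of pyridin-3-yl on an aromatic carbon. The measured steps bear directly on this position, and because a 1.3-fold higher number from compound 1 to compound 2 (0.11 log units; within the scatter) and a 1.3-fold lower number from compound 1 to compound 3 (0.11 log units; within the scatter) both stayed within the scatter, only a small step in this assay is expected for compound 4, with no firm direction. Going by these compounds, the 2-hydroxyquinolin-4-yl group is larger than any group measured, so that part of the change is untested. Compound 4 is therefore expected to give 55 ug/mL, within 28 ug/mL to 110 ug/mL, an estimated step of a 1.2-fold lower number from compound 1 to compound 4 (0.06 log units; within the scatter).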

Compound 4, half-maximal inhibitory concentration: 44.8 ug/mL
For compound 4 the middle estimate is 1.2-fold (0.09 log units) above the measured one; measured number inside the range.
By their numbers in this assay, from the lowest: compounds 4, 3, 1 and 2 (each within the scatter of the next).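

Compound 4 carries two six-membered aromatic rings in the group on this aromatic carbon, opposite the ring nitrogen, whereas the earlier groups each held one. Even so, 2-hydroxyquinolin-4-yl stays within the scatter of all three earlier groups in this assay with a 1.4-fold lower number from compound 1 to compound 4 (0.15 log units; within the scatter) and with a 1.1-fold lower number from compound 3 to compound 4 (0.04 log units; within the scatter) and with a 1.8-fold lower number from compound 2 to compound 4 (0.26 log units; within the scatter) and so this larger group, which also brings a hydrogen-bond donor, does not separate compound 4 from the others. Nothing available explains why these exchanges leave the number within the scatter.

Going by these compounds, what remains open is whether a non-aromatic group on this carbon, such as an amine, a carboxylic acid or a longer alkyl chain, would move the number beyond the scatter. Also open, on these data alone, is whether exchanging the methyl group on the shared core would do so.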